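Adding an Isopropyl Group to Compound 1

A few compounds are considered here, and "the series" means these few. Any claim that something is new, unique, unknown or untested is made for them only; others in the source may bear on it.

Among the compounds with values here, in an assay on cells for inhibition of Palmitoleoyl-protein carboxylesterase NOTUM variant C330S (Homo sapiens), read by fluorescence, with a stated time of 40 min (on this read-out lower numbers stand for stronger inhibition and higher numbers for weaker inhibition), compound 1 `Cc1cc(C(=O)O)c(C)n1-c1ccccc1F` gives 3300 nM, the top of the two numbers measured so far, while compound 2 `Cc1cc(C(=O)O)c(C)n1-c1ccccc1Cl` gives 2300 nM. The step of a 1.4-fold lower number from compound 1 to compound 2 (0.16 log units; within the scatter) involves a chloro in place of fluoro on an aromatic carbon. Compound 3 `Cc1cc(C(=O)O)c(C)n1-c1cccc(C(C)C)c1F` differs from compound 1 by isopropyl in place of hydrogen on an aromatic carbon, an isopropyl in place of hydrogen on an aromatic carbon. Within the data shown here, no measured step involves such an addition, and the halogen swap alone gives no pointer to size or direction. Compound 3 is therefore estimated at 1500 nM, within 300 nM to 7000 nM, an expected step of a 2.2-fold lower number from compound 1 to compound 3 (0.34 log units; beyond the scatter).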

Compound 3, half-maximal inhibitory concentration: 150 nM
For compound 3 the middle estimate is 10-fold (1.00 log units) above the measured one; the whole stated range lies above it.
By their numbers in this assay, from the lowest: compound 3; then compounds 2 and 1 (each within the scatter of the next).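

In this assay, isopropyl in place of hydrogen on an aromatic carbon, ortho to a fluoro group, gives a 22-fold lower number from compound 1 to compound 3 (1.34 log units; beyond the scatter). This shows that the position responds strongly to a carbon substituent, something the halogen swap, made at a different place, could not reveal. No evidence is at hand on what lies behind this gain.

The compounds shown leave open whether a smaller methyl, a larger tert-butyl or a methoxy group at this position would give a similar step. They also leave open whether the step depends on the fluoro group, since isopropyl appears only alongside it.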